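Isopropylsulfanyl in Place of Propoxy, Cytotoxicity Still Unknown

The compounds below may be only part of what the source reports. "The series", "measured", "known", "first", "only" and "open" are said of these compounds alone.

Of the compounds shown here, three sharing one core have been tested in an ADME assay on MOLT-3 cells (Homo sapiens) for cytotoxicity, with a stated time of 7 days; on this read-out higher numbers stand for lower toxicity in this test and lower numbers for higher toxicity in this test. Compound 1 `CCCCCCCCOc1nc(N)nc2c1ncn2/C=C1/CC1(CO)CO` carries an octyloxy group, and in this assay compound 1 gives > 20000 nM, a limit of the assay. Compound 2 `CCCOc1nc(N)nc2c1ncn2/C=C1/CC1(CO)CO` carries a propoxy group, and in this assay compound 2 gives > 20000 nM, again a limit. Compound 3 `Nc1nc(SCc2ccccc2)c2ncn(/C=C3/CC3(CO)CO)c2n1` carries a benzylsulfanyl group, and in this assay compound 3 gives > 20000 nM, also a limit. Compound 2 therefore stands at the limit of > 20000 nM in this assay, at which 3 of the 3 values shown sit, alongside the other two. The steps a step that the two limits leave unreadable from compound 1 to compound 2, a step that the two limits leave unreadable from compound 1 to compound 3 and a step that the two limits leave unreadable from compound 2 to compound 3 all run from one limit to another, so none of them has a readable size or direction. Compound 4 `CC(C)Sc1nc(N)nc2c1ncn2/C=C1/CC1(CO)CO` differs from compound 2 by isopropylsulfanyl in place of propoxy on an aromatic carbon. The step closest in kind is a step that the two limits leave unreadable from compound 2 to compound 3, which is itself unreadable, so the expected step that the limit leaves unreadable from compound 2 to compound 4 cannot be sized from the data. Compound 4 is expected to give about 40000 nM, within 20000 nM to 100000 nM, most probably reported as a further limit.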

Compound 4, half-maximal cytotoxic concentration: > 20000 nM
Compound 4 gave a limit, no number; the forecaster's own chance of this, stated with the estimate: 85%; the middle value is on the limit's open side.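

Compound 4 joins compound 1, compound 2 and compound 3 as a limit rather than a number, so no step among these compounds can be read: the limit of > 20000 nM in this assay, at which 4 of the 4 values shown sit.

The compounds shown leave open where each one truly lies past that limit, and whether swapping these groups changes the read-out at all.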